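Dichlorophenyl in Place of Aminophenyl on the Ketone Carbon

The source may hold more compounds than are shown below. What is called first, only, known or untested is meant among the compounds shown, and "the series" means these compounds.

Measured compounds:
compound 1, `COc1cc(-c2cc(/C=C/C(=O)c3ccc(N)cc3)[nH]n2)cc(OC)c1OC`, 1800 nM in a functional assay on NCI-H460 cells (Homo sapiens) for inhibition, read by sulforhodamine B assay, with a stated time of 48 h; a higher number here means a weaker inhibitor of growth, a lower number a stronger inhibitor of growth
compound 2, `COc1ccc(-c2cc(/C=C/C(=O)c3ccc(OC)c(OC)c3)[nH]n2)cc1`, 1640 nM in this assay

Of the compounds shown here, two have been measured so far. In this assay compound 1 gives 1800 nM, which is the higher of the two numbers, while compound 2 gives 1640 nM. Among the measured compounds shown here, the two values sit within the usual scatter of each other, so nothing can be said about an order between them, and no single-point step between measured compounds is available.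

Compound 3, `COc1cc(-c2cc(/C=C/C(=O)c3ccc(Cl)c(Cl)c3)[nH]n2)cc(OC)c1OC`, has not yet been measured in this assay. It shares the core of compound 1 and differs from it in one place: 3,4-dichlorophenyl in place of 4-aminophenyl on a carbonyl carbon.

Because the two measured values lie within the scatter, the data give no direction for this kind of change. Compound 3 is therefore expected to sit close to compound 1, with the step of a 1.2-fold lower number from compound 1 to compound 3 (0.08 log units; within the scatter) expected to be small and possibly within the scatter in either direction. The estimate for compound 3 in this assay is 1500 nM, with a range from 500 nM to 5000 nM.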

Compound 3, concentration for 50% growth inhibition: 4900 nM
For compound 3 the middle estimate is 3.3-fold (0.51 log units) below the measured one; low and high end bracket the measured number.
By their numbers in this assay, from the lowest: compounds 2 and 1 (each within the scatter of the next); then compound 3.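

In this assay, the group on the carbonyl carbon now shows a readable effect on the number: 3,4-dichlorophenyl in place of 4-aminophenyl gives a 2.7-fold higher number from compound 1 to compound 3 (0.43 log units; beyond the scatter). Among the compounds shown here, this is the first single-place change in the set, and its direction is toward weaker inhibition of growth, so the two aryl groups are not interchangeable on the core of compound 1. The exchange removes the amine and its hydrogen-bond donor and acceptor and brings in two chlorines, but nothing available explains the rise in the number or assigns it to either part of the exchange.

The compounds shown do not separate those two parts, so it remains open how a phenyl ring with a single chlorine, a hydroxyl or an acetamide would read at this position. On these data alone, it is also open whether the same exchange would give a similar step on the other aryl pattern seen in compound 2, which differs from compound 1 in more than one place and therefore offers no reading of this change.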